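Dropping a Chloro Group: Expectations for Compound 3

This account rests on a few compounds, and the source may have more. Where it says the series, first, only, none or still open, it means among the compounds named here.

Of the compounds shown here, two have been tested in a functional assay on HeLa cells (Homo sapiens) for cytotoxicity, read by MTT assay, with a stated time of 24 h; on this read-out higher numbers stand for weaker inhibition and lower numbers for stronger inhibition. Compound 1, `Cc1cc(O)c(C(=O)/C=C/c2ccc(Br)cc2)c(-c2ccc(Br)cc2)c1C(=O)/C=C/c1ccc(Br)cc1`, gives 30000 nM in this assay, a high number and thus a weak effect. Compound 2, `Cc1cc(O)c(C(=O)/C=C/c2ccc3ccccc3c2)c(-c2ccc(Cl)cc2)c1C(=O)/C=C/c1ccc2ccccc2c1`, is recorded in this assay only as "not active" (no number reported), so no single number marks where it stands; all that can be said is that it shows no measurable effect in this test, while compound 1 does carry a value.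

Compound 3, `Cc1cc(O)c(C(=O)/C=C/c2ccc3ccccc3c2)c(-c2ccccc2)c1C(=O)/C=C/c1ccc2ccccc2c1`, has not yet been measured in this assay. It differs from compound 2 in one place: hydrogen in place of chloro on an aromatic carbon. The two structures are otherwise the same.

Among the measured compounds shown here, no measured pair differs in exactly this way, so the size of the step cannot be read from the data. Since compound 2 shows "not active" (no number reported) and compound 1 gives 30000 nM, the expectation is that the swap leaves compound 3 in the same weak region, with no step beyond the scatter in either direction. Compound 3 is therefore estimated at 40000 nM in this assay, within a range from 15000 nM to 120000 nM, with a fair chance that the test again reports no number.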

Compound 3, half-maximal inhibitory concentration: "not active" (no number reported)
Compound 3 has no reported number here; no gap can be computed for the estimate.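

In this assay compound 2 and compound 3 are both recorded as "not active", with no number reported, so no step can be read between them. No available evidence bears on this result. The compounds shown leave open whether going from 4-chlorophenyl to phenyl changes the effect on these cells at all.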